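What One Ring Swap May Do to Cytotoxicity

The compounds below may be only part of what the source reports. "The series", "measured", "known", "first", "only" and "open" are said of these compounds alone.

Toxicity to cells is followed here in an ADME assay on L6 cells (Rattus norvegicus) for cytotoxicity, read by resazurin assay, with a stated time of 72 h (a higher number here means a weaker inhibitor, a lower number a stronger inhibitor), for a small set of compounds. Compound 1 `CC(C)Oc1ccc(C(O)(c2ccc(Cl)cc2)c2cccnc2)cc1` gives 56600 nM as its reading. Compound 2 `OC(c1ccc(C(F)(F)F)cc1)(c1cccnc1)c1ccc(Cl)cc1F` gives > 100000 nM as its result, which is a limit of the assay and not a number. Compound 3 `Cc1ccc(C(O)(c2ccc(OC(C)C)cc2)c2cccnc2)c(F)c1` gives 62600 nM as its reading, level with compound 1 within the scatter.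

Compound 4 `CC(C)Oc1ccc(C(O)(c2cccnc2)c2cnc(Cl)nc2)cc1` has not been measured yet and differs from compound 3 by one group: 2-chloropyrimidin-5-yl in place of 2-fluoro-4-methylphenyl on a saturated chain carbon bound to two aromatic carbons and an oxygen on a saturated carbon. The ring that enters carries hetero atoms and hydrogen-bond acceptors that the leaving ring lacks.

Among the measured compounds shown here, only one measured step changes the group at this same place, swapping 4-chlorophenyl for 2-fluoro-4-methylphenyl. That step, a 1.1-fold higher number from compound 1 to compound 3 (0.04 log units; within the scatter), is a single example and brings in no ring with hetero atoms, so it is a thin guide. On that basis, no step beyond the scatter is expected in this assay for the new swap. The estimated change is a 1.0-fold lower number from compound 3 to compound 4 (0.02 log units; within the scatter) in size. For compound 4 the estimated value is 60000 nM with an expected range from 25000 nM to 100000 nM as the wide allowance for so little evidence.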

Compound 4, half-maximal inhibitory concentration: > 100000 nM
Compound 4 was reported as a limit (the forecaster's own chance of this, stated with the estimate: 25%); middle value at least 1.6-fold (0.22 log units) away from the limit.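

Among the compounds shown here, until now, the only change at this place, on a saturated chain carbon bound to two aromatic carbons and an oxygen on a saturated carbon, swapped one ring of carbon only for another, and it left the reading in this assay within the scatter. For the compounds shown here, compound 4 is the first here to carry a ring with hetero atoms, 2-chloropyrimidin-5-yl, and its result of > 100000 nM is a limit of the assay and not a number. The swap gives an at least 1.5-fold higher number from compound 3 to compound 4 (0.20 log units; that floor lies within the scatter) and an at least 1.7-fold higher number from compound 1 to compound 4 (0.24 log units; that floor lies within the scatter); both are only floors, so the true change could be small or far larger, though the new ring brought no lower number, and the assay's ceiling keeps the real size out of view: the limit of > 100000 nM in this assay, at which 2 of the 4 values shown sit.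

The compounds shown leave open whether the ring's nitrogens or its chlorine matter more for this result. A pyrimidin-5-yl ring without the chlorine, or one with an amine in the chlorine's place, would help separate the two, provided its reading fell under the limit and so gave a real number.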